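Taking one methoxy off compound 3

The compounds below may be only part of what the source reports. "The series", "measured", "known", "first", "only" and "open" are said of these compounds alone.

In a functional assay on HeLa cells (Homo sapiens) for cytotoxicity, read by MTT assay, with a stated time of 48 h (on this read-out lower numbers stand for stronger inhibition and higher numbers for weaker inhibition), compound 3 (`COc1cc(N/C=C\C(=O)c2c(-c3ccc(Cl)cc3)nc3ccccn23)cc(OC)c1OC`) gives 3020 nM. That number lies within the scatter of compound 1 (`COc1ccc(-c2nc3ccccn3c2C(=O)/C=C\Nc2cc(OC)cc(OC)c2)cc1`), which gives 4570 nM. Compound 2 (`COc1ccc(-c2nc3ccccn3c2C(=O)/C=C\Nc2cnc3ccccc3c2)cc1`) reads higher at 9440 nM, beyond the scatter from compound 3.

Compound 4 (`COc1cc(N/C=C\C(=O)c2c(-c3ccc(Cl)cc3)nc3ccccn23)cc(OC)c1`) has not yet been measured. It differs from compound 3 in one place: hydrogen in place of methoxy on an aromatic carbon, ortho to two methoxy groups and para to a large group.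

Within the data shown here, no measured step isolates this change. Among the measured compounds shown here, the only single-place step, a 2.1-fold higher number from compound 1 to compound 2 (0.32 log units; beyond the scatter), is modest and replaces the whole 3,5-dimethoxyphenyl with quinolin-3-yl on an amine nitrogen, a far larger swap than the loss of one methoxy. Compound 1 offers a second, indirect guide, since it carries the same 3,5-dimethoxyphenyl that compound 4 would have. It also differs from compound 4 in another place, yet the value of compound 1, 4570 nM, stays within the scatter of compound 3.

The estimated step is a 1.3-fold higher number from compound 3 to compound 4 (0.10 log units; within the scatter), expected to stay within the scatter and, if anything, to point slightly upward. For compound 4 the expected value is 3800 nM, with an estimated range from 1800 nM to 8000 nM.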

Compound 4, half-maximal inhibitory concentration: 14600 nM
Compound 4: the middle estimate sits 3.8-fold (0.58 log units) below what was measured; the measured number lies above the stated range.
By their numbers in this assay, from the lowest: compounds 3 and 1 (each within the scatter of the next); then compounds 2 and 4 (each within the scatter of the next).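

In this assay, among these compounds, losing the methoxy that sits ortho to two methoxy groups and para to a large group gives a 4.8-fold higher number from compound 3 to compound 4 (0.68 log units; beyond the scatter), the first reading of this position on its own, and it shows that the methoxy there is not a silent passenger. The other new step, a 3.2-fold higher number from compound 1 to compound 4 (0.50 log units; beyond the scatter), comes with chloro in place of methoxy on an aromatic carbon while the 3,5-dimethoxyphenyl stays the same, so compound 4 sits higher than either of its two single-change neighbours, each by a step beyond the scatter. Nothing shown explains why this one small removal counts for so much in the cell read-out.

As far as these compounds go, whether the methoxy at this position could be matched by a hydroxyl, an ethoxy or a fluorine stays open, since only methoxy and hydrogen are compared there. Among the compounds shown here, also open is whether removing this methoxy would cost as much with methoxy in place of the chloro on the other aromatic ring, as the one step that reads the position carries chloro throughout.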